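This account rests on a few compounds, and the source may have more. Where it says the series, first, only, none or still open, it means among the compounds named here.

Within the data shown here, compound 2 `CCNc1cc(-c2ccc(NC(=O)Nc3cccc(Cl)c3)cc2C)ccn1` stands at the top of the three numbers measured so far: in an assay on isolated protein for inhibition of serine/threonine-protein kinase PLK1 (Homo sapiens), read by radiometric assay and 33P incorporation, with a stated time of 40 min, tested at 20 uM, in the presence of a further agent that is not named here (a higher number here means more inhibition at the concentration tested (going by the name of the read-out), a lower number less inhibition), compound 2 gives 82.7%. Compound 3 `CCNc1cc(-c2ccc(NC(=O)Nc3ccccc3Cl)cc2C)ccn1` gives 49.2% in this assay, and compound 1 `CCNc1cc(-c2ccc(NC(=O)Nc3ccc(C)cc3)cc2C)ccn1` gives 47.5%. The measured steps all change the aryl group on the urea nitrogen: a number 35.2 percentage points higher from compound 1 to compound 2 (beyond the scatter), a number 33.5 percentage points lower from compound 2 to compound 3 (beyond the scatter) and a number 1.7 percentage points higher from compound 1 to compound 3 (within the scatter).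

Compound 4 `CCNc1cc(-c2ccc(NC(=O)Nc3cccc(Cl)c3)cc2F)ccn1` keeps the 3-chlorophenyl of compound 2 and differs from it only in fluoro in place of methyl on an aromatic carbon. Among the measured compounds shown here, none of the measured steps touches this place, so no measured step bears directly on the change; the three steps only show that the number in this assay moves widely, higher or lower, with changes on the urea side. With no guidance from the data, the expectation is a step from compound 2 to compound 4 that stays within the scatter or is at most a modest drop, a number 7.7 percentage points lower from compound 2 to compound 4 (within the scatter). Compound 4 is therefore expected to give about 75% in this assay, in a range from 50% to 95%.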

Compound 4, a percentage reported as inhibition, at one concentration (the size of the read-out at that concentration, not a potency): 72.7%
Estimate against measurement, compound 4: 2.3 percentage points above; the measured number falls inside the stated range.
By their numbers in this assay, from the lowest: compounds 1 and 3 (each within the scatter of the next); then compounds 4 and 2 (each within the scatter of the next).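

In this assay, the change of methyl to fluoro on the aromatic carbon ortho to the 2-(ethylamino)pyridin-4-yl group is a number 10 percentage points lower from compound 2 to compound 4 (within the scatter). Among these compounds, this is the first look at this position, and with the 3-chlorophenyl group held constant, the two compounds cannot be told apart here, whereas changing the aryl group on the urea gave large steps. No supporting data bear on what lies behind this result.

The compounds shown leave open whether a plain hydrogen, a chloro group, a methoxy group or an amine at this position would also keep the number in this range. They also leave open whether fluoro and methyl would still match with the 2-chlorophenyl or 4-methylphenyl group on the urea.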